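The source may hold more compounds than are shown below. What is called first, only, known or untested is meant among the compounds shown, and "the series" means these compounds.

Compound 2 `Cc1nn(C)cc1S(=O)(=O)Nc1ccc(Cc2nc3c([nH]2)c(=O)n(Cc2ccccc2F)c(=O)n3CC2CC2)cc1` is one of two measured members of this series. In an assay on H4IIE cells for inhibition of phosphoenolpyruvate carboxykinase, cytosolic [GTP] (Rattus norvegicus) (on this read-out higher numbers stand for an effect only at larger amounts of compound and lower numbers for an effect already at smaller amounts), compound 2 gives 5570 nM, the lowest of the two numbers recorded, although its nearest neighbour, compound 1 `Cn1cc(S(=O)(=O)Nc2ccc(Cc3nc4c([nH]3)c(=O)n(Cc3ccccc3F)c(=O)n4CC3CC3)cc2)cn1`, stands within the scatter: in this assay compound 1 gives 8750 nM. Among the compounds with values here, the single measured step, a 1.6-fold lower number from compound 1 to compound 2 (0.20 log units; within the scatter), comes from a methyl in place of hydrogen on an aromatic carbon, and it does not rise beyond the scatter.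

Compound 3 `Cc1noc(C)c1S(=O)(=O)Nc1ccc(Cc2nc3c([nH]2)c(=O)n(Cc2ccccc2F)c(=O)n3CC2CC2)cc1` differs from compound 2 in one place: 3,5-dimethyl-1,2-oxazol-4-yl in place of 1,3-dimethyl-1H-pyrazol-4-yl on a sulfonyl sulfur. Within the data shown here, no measured step touches this kind of exchange of one five-membered aromatic ring for another on the sulfonyl sulfur; the only measured step concerns a methyl group, and its size, a 1.6-fold lower number from compound 1 to compound 2 (0.20 log units; within the scatter), gives no sign of large movement in this part of the molecule. The expectation for compound 3 in this assay is therefore a change of no more than the scatter, in no settled direction. Compound 3 is estimated at 6000 nM, with a range from 2500 nM to 15000 nM, an expected step of a 1.1-fold higher number from compound 2 to compound 3 (0.03 log units; within the scatter) from compound 2.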

Compound 3, half-maximal effective concentration: 3400 nM
Compound 3: middle estimate off by 1.8-fold (0.25 log units), on the high side; the measured number falls inside the stated range.
By their numbers in this assay, from the lowest: compounds 3, 2 and 1 (each within the scatter of the next, the first and the last beyond it).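

In this assay, 3,5-dimethyl-1,2-oxazol-4-yl in place of 1,3-dimethyl-1H-pyrazol-4-yl on a sulfonyl sulfur gives a 1.6-fold lower number from compound 2 to compound 3 (0.21 log units; within the scatter), so this first exchange of one five-membered aromatic ring for another does not separate the two compounds, even though the ring atoms change from two nitrogens to one nitrogen and one oxygen. Within the data shown here, measured against the 1-methyl-1H-pyrazol-4-yl group at the same place, the exchange gives a 2.6-fold lower number from compound 1 to compound 3 (0.41 log units; beyond the scatter), the first step to pass the scatter, which shows that the group on the sulfonyl sulfur can move the number in this assay, if only modestly. Nothing available explains this difference between the groups.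

The compounds shown all carry a methyl-bearing five-membered aromatic ring on the sulfonyl sulfur, so they leave open how far the number would move with a six-membered ring such as phenyl or pyridine, or with a ring-free group such as an ethyl chain. They also leave open what each methyl on the 1,2-oxazole contributes, and whether an amine or a carboxylic acid on that ring would be accommodated.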